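The source may report more compounds than this note shows. Statements on the series, on what has been measured and on what is new or still open speak of the compounds shown alone.

In a toxicity assay on HepG2 2.2.15 cells (Homo sapiens) for cytotoxicity, read by CellTiter-Glo (a lower number here means that less compound is tolerated, a higher number that more compound is tolerated), three compounds built on a shared core have been measured. Compound 1 `N#CC1CC(=O)N(c2cnn3c2CN(C(=O)Nc2cc(F)c(F)c(F)c2)C(C2CC2)C3)C1` gives > 200000 nM, which is a limit of the assay and not a number. Compound 2 `O=C1CC(c2cnc(C(F)(F)F)s2)CN1c1cnn2c1CN(C(=O)Nc1cc(F)c(F)c(F)c1)C(C1CC1)C2` gives 38500 nM. Compound 3 `O=C(Nc1cc(F)c(F)c(F)c1)N1Cc2c(-c3ccc(F)cc3)cnn2CC1C1CC1` gives 38500 nM, which puts it level with compound 2.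

The next compound starts from compound 3. Compound 4 `O=C1CC(c2ccccc2)CN1c1cnn2c1CN(C(=O)Nc1cc(F)c(F)c(F)c1)C(C1CC1)C2` carries 2-oxo-4-phenylpyrrolidin-1-yl in place of 4-fluorophenyl on an aromatic carbon.

Within the data shown here, two measured steps bear on this change. Putting 2-(trifluoromethyl)-1,3-thiazol-5-yl in place of cyano on a saturated ring carbon gave an at least 5.1-fold lower number from compound 1 to compound 2 (0.71 log units; beyond the scatter). Putting 4-fluorophenyl in place of 4-cyano-2-oxopyrrolidin-1-yl on an aromatic carbon gave an at least 5.1-fold lower number from compound 1 to compound 3 (0.71 log units; beyond the scatter). Both steps start from the same limit, so their true sizes are not known.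

Compound 4 keeps the oxopyrrolidine ring of compound 1, but like compound 2 it has an aromatic ring on that ring where compound 1 has cyano. It therefore looks closer to compound 2, at 38500 nM, than to compound 1. No step beyond the scatter is expected in this assay, and the estimated step is a 1.4-fold higher number from compound 3 to compound 4 (0.15 log units; within the scatter). For compound 4 the expected value is 55000 nM, with an estimated range from 25000 nM to 150000 nM.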

Compound 4, half-maximal cytotoxic concentration: 12800 nM
Estimate against measurement, compound 4: 4.3-fold (0.63 log units) above; the measured number lies below the stated range.
By their numbers in this assay, from the lowest: compound 4; then compounds 2 and 3 (each within the scatter of the next). At a limit, above all of these: compound 1.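

In this assay, the place on the aromatic carbon of the five-membered aromatic ring now shows a readable change: 2-oxo-4-phenylpyrrolidin-1-yl in place of 4-fluorophenyl gives a 3.0-fold lower number from compound 3 to compound 4 (0.48 log units; beyond the scatter), whereas compound 2 and compound 3 had stood level. Within the oxopyrrolidine series, compound 2 and compound 4 also show that the identity of the aromatic ring on the saturated ring carbon matters, as phenyl in place of 2-(trifluoromethyl)-1,3-thiazol-5-yl gives a 3.0-fold lower number from compound 2 to compound 4 (0.48 log units; beyond the scatter). Phenyl in place of cyano on that same carbon gives an at least 15-fold lower number from compound 1 to compound 4 (1.19 log units; beyond the scatter), but this step starts from a limit for compound 1 and not from a number, so its true size remains unknown: the limit of > 200000 nM in this assay, at which 1 of the 4 values shown sits.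

From the compounds shown here alone, it remains open whether a small non-aromatic group on the saturated ring carbon, such as methyl or an amine, would give a number closer to that of compound 1 or to that of compound 4. Going by these compounds, it is also open whether a fluorine or a carboxylic acid on the phenyl ring of compound 4 would move the number in this assay.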